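This account rests on a few compounds, and the source may have more. Where it says the series, first, only, none or still open, it means among the compounds named here.

Measured so far:
Compound 1, `COc1cc(OC)c(C(=O)/C=C/c2ccc(Cl)cc2)c(OC)c1`: 6000 nM
Compound 2, `COc1cc(O)c(C(=O)/C=C/c2ccccc2SC)c(OC)c1`: 9000 nM

Both numbers come from a functional assay on NCI-H727 cells (Homo sapiens) for cytotoxicity, with a stated time of 48 h; a higher number here means a weaker inhibitor, a lower number a stronger inhibitor. Compound 1 has the lower of the two numbers, but the number for compound 2 sits close to it, within the usual scatter of repeated measurements, so no order between the two compounds can be claimed.

Compound 3, `COc1cc(OC)c(C(=O)/C=C/c2ccccc2)c(OC)c1`, has not yet been measured in this assay. It differs from compound 1 in one place: hydrogen in place of chloro on an aromatic carbon. Among the measured compounds shown here, no pair of measured compounds differing in one place is available to show what such a change does here, and compound 2 differs from compound 1 in several ways at once, so it gives no guide. The step of a 1.3-fold higher number from compound 1 to compound 3 (0.12 log units; within the scatter) is expected to be small, toward a slightly higher number, and not clearly beyond the scatter. Compound 3 is therefore expected to give about 8000 nM, with a range from 3000 nM to 20000 nM.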

Compound 3, half-maximal inhibitory concentration: 11400 nM
Beside the measured number, compound 3's estimate is 1.4-fold (0.15 log units) below it; the range from low to high includes it.
By their numbers in this assay, from the lowest: compounds 1, 2 and 3 (each within the scatter of the next).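

Among the compounds shown here, compound 1 and compound 3 form the first pair that differs in one place only, so the exchange of chloro for hydrogen on this aromatic carbon can be read on its own. In this assay, this exchange gives a 1.9-fold higher number from compound 1 to compound 3 (0.28 log units; within the scatter) and so the two compounds cannot be told apart, which means that the chloro at this position is not shown to matter in this assay. Nothing available here offers an explanation for this result.

For the compounds shown here, the single pair cannot show whether the same exchange would read alike on a different core. It also leaves open whether an amine or a carboxylic acid on this carbon would give a number clearly apart from those of compound 1 and compound 3.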